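A few compounds are considered here, and "the series" means these few. Any claim that something is new, unique, unknown or untested is made for them only; others in the source may bear on it.

In a physicochemical assay for solubility, read by HPLC, in phosphate buffer, with a stated time of 24 h, at pH 6.5 (a higher number here means a more soluble compound, a lower number a less soluble compound), compound 1 `CCCS(=O)(=O)Nc1ccc(F)c(C(=O)Nc2cnc3[nH]ncc3c2)c1F` gives 80 ug/mL and compound 2 `CCCS(=O)(=O)Nc1ccc(F)c(C(=O)Nc2cnc3[nH]nc(C)c3c2)c1F` gives 380 ug/mL, the higher of the two actual numbers. Compound 3 `CCCS(=O)(=O)Nc1ccc(F)c(C(=O)Nc2cnc3[nH]cc(Br)c3c2)c1F` gives < 1 ug/mL, which is a limit of the assay and not a number. Compound 4 `CCCS(=O)(=O)Nc1ccc(F)c(C(=O)Nc2cnc3[nH]nc(OC)c3c2)c1F` differs from compound 2 by methoxy in place of methyl on an aromatic carbon, with methoxy in place of methyl on an aromatic carbon. Within the data shown here, the only measured step that bears on this change is a 4.8-fold higher number from compound 1 to compound 2 (0.68 log units; beyond the scatter), where methyl takes the place of hydrogen on an aromatic carbon. Among the measured compounds shown here, with compound 2 at the top and only that modest step as a guide, a modest drop is expected in this assay. The estimated step is a 1.9-fold lower number from compound 2 to compound 4 (0.28 log units; within the scatter). For compound 4 the estimated value is 200 ug/mL, with an expected range of 50 ug/mL to 700 ug/mL.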

Compound 4, solubility: 4 ug/mL
For compound 4 the middle estimate is 50-fold (1.70 log units) above the measured one, and the stated range ends above it.
By their numbers in this assay, from the lowest: compound 4; then compound 1; then compound 2. At a limit, below all of these: compound 3.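

In this assay, methoxy in place of methyl gives a 95-fold lower number from compound 2 to compound 4 (1.98 log units; beyond the scatter), a large fall for a change that adds only one oxygen atom. Methoxy in place of hydrogen on the same aromatic carbon also lowers the number, with a 20-fold lower number from compound 1 to compound 4 (1.30 log units; beyond the scatter), so this position can send the number up or down according to the group on it. Nothing shown here accounts for the size of this fall.

The compounds shown leave open how an amine or an ethyl group on this carbon would compare with methyl and methoxy. They also leave open whether methoxy on another part of the shared core would give a step of this size.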